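Series notes: para substituent on the triazolyl phenyl ring

The source may hold more compounds than are shown below. What is called first, only, known or untested is meant among the compounds shown, and "the series" means these compounds.

Measured so far:
compound 1 `Cc1ccc(-n2cc(CNC(=O)c3c[nH]c(-c4ccccc4)n3)nn2)cc1` — 409000 nM
compound 2 `COc1ccc(-n2cc(CNC(=O)c3c[nH]c(-c4ccccc4)n3)nn2)cc1` — 388000 nM

In an ADME assay on Vero cells (Chlorocebus sabaeus) for cytotoxicity, read by MTT assay, with a stated time of 72 h (on this read-out lower numbers stand for stronger inhibition and higher numbers for weaker inhibition), compound 2 gives the lowest of the two numbers, yet it sits within the scatter of compound 1, with a 1.1-fold lower number from compound 1 to compound 2 (0.02 log units; within the scatter). Among the measured compounds shown here, compound 3 `NC(=O)c1ccc(-n2cc(CNC(=O)c3c[nH]c(-c4ccccc4)n3)nn2)cc1` takes the next step on the same ring: carbamoyl in place of methoxy on an aromatic carbon The only step seen here, methoxy in place of methyl, stayed within the scatter; no step has yet exchanged the group for one carrying a hydrogen-bond donor. On that basis no movement beyond the scatter is expected, a 1.0-fold higher number from compound 2 to compound 3 (0.01 log units; within the scatter), and compound 3 is estimated at 400000 nM in this assay, between 200000 nM and 800000 nM.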

Compound 3, half-maximal inhibitory concentration: 198000 nM
Beside the measured number, compound 3's estimate is 2.0-fold (0.31 log units) above it; measured number outside the range, below it.
By their numbers in this assay, from the lowest: compounds 3, 2 and 1 (each within the scatter of the next, the first and the last beyond it).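

In this assay, carbamoyl on this aromatic carbon, para to a large group, stays within the scatter of methoxy (a 2.0-fold lower number from compound 2 to compound 3 (0.29 log units; within the scatter)). Against methyl, the same group gives the first step beyond the scatter in the series, though a modest one (a 2.1-fold lower number from compound 1 to compound 3 (0.32 log units; beyond the scatter)). Nothing available accounts for this difference.

Open, from the compounds shown here alone, is whether a carboxylic acid or an amine on the same carbon would extend the step beyond the scatter of methoxy. Also open, going by these compounds, is whether carbamoyl would give a similar number elsewhere on the ring.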